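The source may hold more compounds than are shown below. What is called first, only, known or untested is meant among the compounds shown, and "the series" means these compounds.

Compound 1 `Cc1ccc(S(=O)(=O)Nc2ccc(-c3ccccc3N3CCCCC3)nn2)cc1` holds the lowest of the two numbers measured in an assay on mitochondria from liver for inhibition of kynurenine 3-monooxygenase (Mus musculus), read by LC-MS, with stated times of 5 min and 30 min (a higher number here means a weaker inhibitor, a lower number a stronger inhibitor), so far: compound 1 gives 2.4 nM, whereas compound 2 `Cc1ccc(S(=O)(=O)Nc2ccc(-c3cccc4ccn(C)c34)nn2)cc1` gives 29.1 nM, a gap beyond the usual scatter. Compound 3 `CCc1ccccc1-c1ccc(NS(=O)(=O)c2ccc(C)cc2)nn1` differs from compound 1 in one place: ethyl in place of piperidin-1-yl on an aromatic carbon. Within the data shown here, no pair of measured compounds shows this change, so its size is not known from the data. The expected step in this assay is a 3.3-fold higher number from compound 1 to compound 3 (0.52 log units; beyond the scatter), a modest move toward a higher number. Compound 3 is accordingly estimated at 8 nM, with a range from 2 nM to 30 nM.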

Compound 3, half-maximal inhibitory concentration: 29.2 nM
The estimate for compound 3 lay 3.7-fold (0.56 log units) below the measured number, within the range that was stated.
By their numbers in this assay, from the lowest: compound 1; then compounds 2 and 3 (each within the scatter of the next).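

In this assay, ethyl in place of piperidin-1-yl on this aromatic carbon, ortho to a large group, gives a 12-fold higher number from compound 1 to compound 3 (1.09 log units; beyond the scatter) and so counts as a large step. Among these compounds, this is the first direct reading at this position, and it shows that the number responds strongly to the group placed there: here, a short chain cannot stand in for the six-membered non-aromatic ring. No measurement shown accounts for the size of this step. Going by these compounds, it remains open whether a cyclohexyl ring, a morpholin-4-yl group or a longer chain such as butyl on this carbon would keep the lower number of compound 1.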